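Aryl Variation on the Shared Core: Compound 1 to Compound 4

The compounds below may be only part of what the source reports. "The series", "measured", "known", "first", "only" and "open" are said of these compounds alone.

Compound 1 `COC(=O)c1sc2cc(-c3ccsc3)cnc2c1N` is the only one of the three measured compounds that returns a number in a functional assay on MCF7 cells (Homo sapiens) for inhibition, read by sulforhodamine B assay, with a stated time of 48 h; a lower number here means a stronger inhibitor of growth, a higher number a weaker inhibitor of growth: compound 1 gives 12700 nM. Compound 2 `COC(=O)c1sc2cc(-c3ccc(OC)nc3)cnc2c1N` reaches only a limit of the assay, and in this assay compound 2 gives > 37500 nM. Compound 3 `COC(=O)c1sc2cc(-c3cnc(OC)nc3OC)cnc2c1N` likewise reaches only a limit, and in this assay compound 3 gives > 75000 nM. For the measured compounds named here, these two limits (the limit of > 37500 nM in this assay, at which 1 of the 3 values shown sits, and (the limit of > 75000 nM in this assay, at which 1 of the 3 values shown sits)) mark the edge of what the assay reports, so compound 1 stands as the single compound with a measured value, and the two others cannot be ranked against it beyond the fact that they gave no number.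

Compound 4 `COC(=O)c1sc2cc(-c3ccccc3N)cnc2c1N` has not yet been measured in this assay. It differs from compound 1 in one place: 2-aminophenyl in place of thiophen-3-yl on an aromatic carbon. Going by the values given here, no step between measured compounds that differ in one place is available, so the size of this change cannot be read from the data. The step of a 1.3-fold lower number from compound 1 to compound 4 (0.10 log units; within the scatter) is expected to lie within the usual scatter, with no clear direction. Compound 4 is estimated at 10000 nM, within a range from 3000 nM to 40000 nM.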

Compound 4, concentration for 50% growth inhibition: 4200 nM
The estimate for compound 4 lay 2.4-fold (0.38 log units) above the measured number; the measured number falls inside the stated range.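

In this assay, for the compounds shown here, the change from thiophen-3-yl to 2-aminophenyl on an aromatic carbon, two atoms from the ring nitrogen, gives the first step that can be read at this position: a 3.0-fold lower number from compound 1 to compound 4 (0.48 log units; beyond the scatter). The step is modest but beyond the scatter, and it shows that this position can carry a six-membered aromatic ring of carbon only, bearing an amine, and still return a measured number, with the number moving down rather than up. Nothing measured in this set says why the number falls with this change.

Going by these compounds, whether the step belongs to the amine or to the phenyl ring stays open, as the change brings in both at once, and a plain phenyl at this position, or a carboxylic acid in place of the methyl ester on the shared core, would be needed to say more. The steps to compound 2 and compound 3 cannot be read, as both of these compounds stand only at limits of the assay.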